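This account rests on a few compounds, and the source may have more. Where it says the series, first, only, none or still open, it means among the compounds named here.

Of the compounds shown here, three of one shared core have been tested in a functional assay on the whole organism (strain Wister albino) for inhibition, with Rattus norvegicus as the target, read by paw edema, with a stated time of 1 h, at a dose of 50 mg/kg by the intraperitoneal route; a higher number here means more inhibition at the dose given (going by the name of the read-out), a lower number less inhibition. Compound 1 `CN1C[C@@H](c2ccccc2)[C@@]2(Cc3ccccc3C2=O)[C@@]12C(=O)Nc1ccccc12` gives 56%. Compound 2 `CN1C(=O)[C@@]2(c3ccccc31)N(C)C[C@@H](c1ccco1)[C@@]21Cc2ccccc2C1=O` gives 50.1%. Compound 3 `CN1C(=O)[C@@]2(c3ccccc31)N(C)C[C@@H](c1ccc(F)cc1)[C@@]21Cc2ccccc2C1=O` gives 52.9%. Compound 1 has the highest of the three numbers, yet its distances to compound 3 and to compound 2 both lie within the scatter, so the three cannot be ordered.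

Compound 4 `CN1C[C@@H](c2cccs2)[C@@]2(Cc3ccccc3C2=O)[C@@]12C(=O)Nc1ccccc12` has not been measured. It differs from compound 1 in one place: thiophen-2-yl in place of phenyl on a saturated ring carbon. Within the data shown here, the only measured step that changes the group on this saturated ring carbon is a number 2.8 percentage points higher from compound 2 to compound 3 (within the scatter), which stays within the scatter. An exchange of one ring for another at this place has thus left this assay essentially unmoved in the one case on record, and a similar outcome is expected here, namely a number 3 percentage points lower from compound 1 to compound 4 (within the scatter), without a direction that could be read beyond the scatter. For compound 4 the estimate is 53%, with a range from 44% to 62%.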

Compound 4, a percentage reported as inhibition, in the whole organism at one dose (the size of the read-out at that dose, not a potency): 49.9%
Compound 4: the middle estimate sits 3.1 percentage points above what was measured, within the range that was stated.
By their numbers in this assay, from the lowest: compounds 4, 2, 3 and 1 (each within the scatter of the next).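

In this assay, thiophen-2-yl in place of phenyl on the saturated ring carbon gives a number 6.1 percentage points lower from compound 1 to compound 4 (within the scatter), so a second ring exchange at this place also stays within the scatter, this time on the core of compound 1 rather than on that of compound 2. The change from a six-membered aromatic ring of carbon only to a five-membered aromatic ring with one hetero atom, which brings in one hydrogen-bond acceptor, thus leaves no readable mark at this dose. No measurement at hand offers an explanation for this result.

From the compounds shown here alone, all four compounds carry an aromatic ring on this carbon, so it remains open whether an amine, a carboxylic acid or a longer alkyl chain there would shift the number beyond the scatter. Also open, going by these compounds, is how these compounds compare at other doses or times, as one dose gives no potency.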